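The source may hold more compounds than are shown below. What is called first, only, known or untested is meant among the compounds shown, and "the series" means these compounds.

The three measured compounds share one core. Compound 1 `Cc1ccc2nc(C)c(C(=O)NCCOc3ccc(Br)cc3)n2c1` gives 0.108 h in an ADME assay on cells (Hepatocyte, Homo sapiens) for metabolic stability; on this read-out higher numbers stand for a longer-lived compound and lower numbers for a shorter-lived compound. For the measured compounds named here, compound 3 `COc1ccc2nc(C)c(C(=O)NCCOc3ccc(Br)cc3)n2c1` gives 0.903 h in this assay, and the single change between the two, methoxy in place of methyl on an aromatic carbon, brings an 8.4-fold higher number from compound 1 to compound 3 (0.92 log units; beyond the scatter). Compound 2 `CCc1nc2ccc(C)cn2c1C(=O)NCCOc1ccc(OC)cc1` gives 0.325 h in this assay and stands second highest of the three numbers, beyond the scatter below compound 3 and beyond the scatter above compound 1. Compound 4 `COc1ccc(OCCNC(=O)c2c(C3CC3)nc3ccc(C)cn23)cc1` differs from compound 2 in one place only: cyclopropyl in place of ethyl on an aromatic carbon. Going by the values given here, no measured pair shows an exchange of ethyl for cyclopropyl, and the only measured step concerns methoxy against methyl at another place, so it offers no guidance here. With nothing to lean on, the exchange is expected to leave this assay essentially where it was, a 1.2-fold higher number from compound 2 to compound 4 (0.09 log units; within the scatter). Compound 4 is therefore estimated at 0.4 h, with a range from 0.15 h to 1.1 h.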

Compound 4, half-life: 0.13 h
Beside the measured number, compound 4's estimate is 3.1-fold (0.49 log units) above it; the measured number lies below the stated range.
By their numbers in this assay, from the lowest: compounds 1 and 4 (each within the scatter of the next); then compound 2; then compound 3.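

For the compounds shown here, this is the first measured change at this aromatic carbon of the five-membered aromatic ring, and it shows that the place is not indifferent in this assay: cyclopropyl in place of ethyl brings a 2.5-fold lower number from compound 2 to compound 4 (0.40 log units; beyond the scatter). The exchange adds one carbon and a three-membered ring but leaves the counts of hydrogen-bond donors and acceptors at zero, so the step comes with no difference in those counts. No available measurement accounts for this step, and its cause remains unknown.

Going by these compounds, whether the step follows from the ring itself or from the added carbon stays open, and propyl or isopropyl at this place would help to separate the two. Also open, on these data alone, is whether the same exchange would give a similar step on compound 3.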